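This account rests on a few compounds, and the source may have more. Where it says the series, first, only, none or still open, it means among the compounds named here.

Working notes on the series. Compound 2 `COc1ccccc1C(=O)N/N=C/c1ccc(-c2ccc(F)cc2F)o1` gives 10.1% in a functional assay on KB cells (Homo sapiens) for inhibition, read by sulforhodamine B assay, with a stated time of 48 h, tested at 10 uM; on this read-out higher numbers stand for more inhibition of growth at the one concentration tested and lower numbers for less inhibition of growth. Compound 1 `O=C(N/N=C/c1ccc(-c2ccc(F)cc2F)o1)c1ccccc1O` gives 61.8% in this assay; the change between them hydrogen in place of methyl on an oxygen on an aromatic ring made a step of a number 51.7 percentage points higher from compound 2 to compound 1 (beyond the scatter). Compound 3 `COc1ccccc1/C=N/NC(=O)c1ccc(-c2ccc(F)cc2F)o1` gives 59.5% in this assay; the difference between its core and that of compound 2 is not broken down here. Compound 4 `O=C(N/N=C/c1ccccc1O)c1ccc(-c2ccc(F)cc2F)o1` is not yet measured; it differs from compound 3 by hydrogen in place of methyl on an oxygen on an aromatic ring, at the same place as the earlier change, so it is the same change. Because compound 3 already gives 59.5%, a step as large as a number 51.7 percentage points higher from compound 2 to compound 1 (beyond the scatter) cannot repeat in full, so a smaller upward step of a number 18.5 percentage points higher from compound 3 to compound 4 (beyond the scatter) is expected. Compound 4 is estimated at 78%, between 55% and 98%.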

Compound 4, percent growth inhibition at one concentration: 75.3%
Beside the measured number, compound 4's estimate is 2.7 percentage points above it, within the range that was stated.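

Methoxy to hydroxy again moves the read-out upward in this assay, a step of a number 15.8 percentage points higher from compound 3 to compound 4 (beyond the scatter). The direction of the change carries over from one core to the other, but its size does not: the same change on two cores in this assay, a number 51.7 percentage points higher (beyond the scatter) from compound 2 to compound 1 and a number 15.8 percentage points higher (beyond the scatter) from compound 3 to compound 4, 35.9 percentage points apart, beyond the scatter of two such steps Two pairs do not show why the size differs, nor whether the upward direction would hold on any further core in this series.

The compounds shown leave open how an amine or an ethoxy group would compare with hydroxy at this place on either core. Also open, from the compounds shown here alone, is whether the gap between the two steps would persist at concentrations other than the single one tested.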